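This account rests on a few compounds, and the source may have more. Where it says the series, first, only, none or still open, it means among the compounds named here.

Compound 1, `O=C1c2c(O)cc(O)cc2O[C@H](c2cccc(O)c2)[C@H]1O`, carries a single hydroxy group on its pendant aromatic ring. In a physicochemical assay, read by spectrophotometry, with a stated time of 30 min (a higher number here means that more compound is needed for the effect, a lower number that less compound is needed), compound 1 reaches only a limit of the assay, > 100000 nM. Compound 2, `O=C1c2c(O)cc(O)cc2O[C@H](c2cc(O)cc(O)c2)[C@H]1O`, adds a hydroxy in place of hydrogen on an aromatic carbon of that ring. In this assay compound 2 likewise reaches only a limit, > 100000 nM. The step that the two limits leave unreadable from compound 1 to compound 2 is therefore unreadable, since both ends sit at a limit. Compound 2 thus stands at the limit of > 100000 nM in this assay, at which 2 of the 2 values shown sit, and nothing in the measured material places it more precisely.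

Compound 3, `O=C1c2c(O)cc(O)cc2O[C@@H](c2cc(O)cc(O)c2)[C@@H]1O`, is the mirror image of compound 2: the two compounds have the same atoms and bonds and differ only in configuration as drawn: 2 of 2 stereo elements differ (all stereocentres are inverted: mirror images); a stereocentre at a saturated ring carbon is drawn R in compound 2 and S in compound 3; a stereocentre at a saturated ring carbon is drawn R in compound 2 and S in compound 3. Among the measured compounds shown here, no measured step concerns a change of configuration; the only measured step, from a hydroxy added to an aromatic ring, could not be read because both values were limits. What is known of compound 2 is a limit only, so the expectation for compound 3 rests on that limit alone. Compound 3 is therefore expected to stay at the same limit in this assay, with an expected step that the limit leaves unreadable from compound 2 to compound 3 that is not beyond the scatter. The estimate for compound 3 in this assay is 200000 nM, with a range from 60000 nM to 1000000 nM.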

Compound 3, half-maximal effective concentration: > 100000 nM
Compound 3 was reported as a limit; the forecaster's own chance of this, stated with the estimate: 85%; the middle value lies beyond the limit too.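

In this assay compound 3 gives only a limit, > 100000 nM. Among the compounds shown here, with both mirror images at a limit, no step from compound 2 to compound 3 can be read. The compounds shown leave open how much of any of them would be needed for the effect, and whether compound 2 and compound 3 differ at all.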